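Adding bromo to compound 3

This account rests on a few compounds, and the source may have more. Where it says the series, first, only, none or still open, it means among the compounds named here.

Measured in a functional assay on MT4 cells (Homo sapiens) for cytotoxicity; on this read-out higher numbers stand for weaker inhibition and lower numbers for stronger inhibition:
Compound 1 `Cc1cc(O)cc(S(=O)(=O)c2cccc(N)c2C#N)c1`: 167000 nM
Compound 2 `CCOc1cc(C)cc(S(=O)(=O)c2cccc(N)c2C#N)c1`: 9000 nM
Compound 3 `Cc1cccc(S(=O)(=O)c2cccc(N)c2C#N)c1`: 179000 nM

Compound 3, at 179000 nM, shares the top of this small set with one other compound: the data show a 1.1-fold higher number from compound 1 to compound 3 (0.03 log units; within the scatter). The gap to the remaining compound is large, with a 20-fold higher number from compound 2 to compound 3 (1.30 log units; beyond the scatter).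

The next compound, compound 4 `Cc1cc(Br)cc(S(=O)(=O)c2cccc(N)c2C#N)c1`, carries bromo in place of hydrogen on an aromatic carbon. Going by the values given here, this is the carbon that bears hydroxy in compound 1 and ethoxy in compound 2, so those two steps are the closest guides, although no measured compound carries bromo. They disagree: the hydroxy pair gives a 1.1-fold higher number from compound 1 to compound 3 (0.03 log units; within the scatter), whereas the ethoxy pair gives a 20-fold higher number from compound 2 to compound 3 (1.30 log units; beyond the scatter). A step between these two outcomes therefore seems the fair expectation, moderate in size and towards a lower number in this assay. The expected change is a 4.0-fold lower number from compound 3 to compound 4 (0.60 log units; beyond the scatter). For compound 4 the estimated value is 45000 nM, with an expected range from 10000 nM to 170000 nM.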

Compound 4, half-maximal inhibitory concentration: 133000 nM
Compound 4: middle estimate off by 3.0-fold (0.47 log units), on the low side; low and high end bracket the measured number.
By their numbers in this assay, from the lowest: compound 2; then compounds 4, 1 and 3 (each within the scatter of the next).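

In this assay, bromo on this aromatic carbon cannot be told apart from hydrogen (a 1.3-fold lower number from compound 3 to compound 4 (0.13 log units; within the scatter)) or from hydroxy (a 1.3-fold lower number from compound 1 to compound 4 (0.10 log units; within the scatter)). Ethoxy alone stands apart among the groups shown at this position (a 15-fold higher number from compound 2 to compound 4 (1.17 log units; beyond the scatter)), so the lower number of compound 2 is not matched by every replacement for hydrogen here, and compound 4 joins compounds 1 and 3 against that single low value. Nothing available here explains why ethoxy differs from bromo at this carbon.

The compounds shown leave open whether the lower number belongs to ethoxy alone or also extends to methoxy, propoxy or a longer alkoxy chain. They also do not show whether an amine, chloro or fluoro at this carbon would group with compound 4 or with compound 2.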